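The compounds below may be only part of what the source reports. "The series", "measured", "known", "first", "only" and "open" are said of these compounds alone.

Of the compounds shown here, two have been measured in a functional assay on HOP-92 cells (Homo sapiens) for inhibition, read by sulforhodamine B assay, with a stated time of 48 h; a lower number here means a stronger inhibitor, a higher number a weaker inhibitor. Compound 1, with structure `O=C(Nc1cccc(-n2cc(-c3ccncc3)c(-c3ccc(Cl)c(O)c3)n2)c1)Nc1cccc(C(F)(F)F)c1`, gives 510 nM in this assay. Compound 2, with structure `COc1cc(-c2nn(-c3cccc(NC(=O)Nc4ccc(Cl)c(Cl)c4)c3)cc2-c2ccncc2)ccc1Cl`, gives 150 nM in this assay. Compound 2 therefore stands at the lower of the two numbers, and the gap to compound 1 lies beyond the usual scatter of this kind of measurement.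

The unmeasured compound 3, with structure `COc1cc(-c2nn(-c3cccc(NC(=O)Nc4cccc(C(F)(F)F)c4)c3)cc2-c2ccncc2)ccc1Cl`, is reached from compound 2 by a single change: 3-(trifluoromethyl)phenyl in place of 3,4-dichlorophenyl on an amide-type nitrogen. Everything else in the molecule stays as it is in compound 2.

No direct comparison of exactly this change is available among the measured compounds. Compound 1 does carry the same 3-(trifluoromethyl)phenyl group on its amide-type nitrogen, but it also differs from compound 3 elsewhere, so its value only hints at the outcome. The step from compound 2 to compound 3 is expected to be a 1.7-fold higher number from compound 2 to compound 3 (0.24 log units; within the scatter), a modest move toward a weaker inhibitor that may not clear the scatter. Compound 3 is accordingly expected to give about 260 nM in this assay, with a likely range from 110 nM to 650 nM.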

Compound 3, half-maximal inhibitory concentration: 560 nM
Compound 3: middle estimate off by 2.2-fold (0.33 log units), on the low side; the measured number falls inside the stated range.
By their numbers in this assay, from the lowest: compound 2; then compounds 1 and 3 (each within the scatter of the next).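

In this assay, the change at the amide-type nitrogen from 3,4-dichlorophenyl to 3-(trifluoromethyl)phenyl gives a 3.7-fold higher number from compound 2 to compound 3 (0.57 log units; beyond the scatter) as a direct step, so this position responds to the exchange and the 3,4-dichlorophenyl compound is the stronger inhibitor of this pair. With 3-(trifluoromethyl)phenyl held in place, methyl in place of hydrogen on an oxygen on an aromatic ring gives a 1.1-fold higher number from compound 1 to compound 3 (0.04 log units; within the scatter) and leaves no readable difference, so that oxygen tolerates this small change while the group on the amide-type nitrogen makes a clear difference. Nothing among the data shown accounts for why either step has the size it does.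

Among these compounds, only two groups are compared on the amide-type nitrogen, so it remains open how a plain phenyl or a cyclohexyl group would behave there. The step on the oxygen is also seen only alongside 3-(trifluoromethyl)phenyl, which leaves open whether it would look the same alongside 3,4-dichlorophenyl, and whether an ethyl group on that oxygen would change the number.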